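Turning the double bond of compound 3

The source may report more compounds than this note shows. Statements on the series, on what has been measured and on what is new or still open speak of the compounds shown alone.

Measured so far in a functional assay on HT-29 cells (Homo sapiens) for inhibition (on this read-out higher numbers stand for weaker inhibition and lower numbers for stronger inhibition), each reading a limit:
- compound 1 `COc1c([N+](=O)[O-])cc(/C=C/c2ccc3ccccc3c2)cc1[N+](=O)[O-]` gives > 5000 nM as a limit
- compound 2 `COc1c([N+](=O)[O-])cc(/C=C\c2ccc3ccccc3c2)cc1[N+](=O)[O-]` gives > 5000 nM as a limit
- compound 3 `CN(C)c1c([N+](=O)[O-])cc(/C=C/c2ccc3ccccc3c2)cc1[N+](=O)[O-]` gives > 5000 nM as a limit

Compound 3 has no number of its own, only the limit > 5000 nM in this assay as its reading. Compound 4 `CN(C)c1c([N+](=O)[O-])cc(/C=C\c2ccc3ccccc3c2)cc1[N+](=O)[O-]` differs from compound 3 by one change (the two compounds have the same atoms and bonds and differ only in configuration as drawn: 1 of 1 stereo elements differ; a double bond is drawn E in compound 3 and Z in compound 4), a double bond drawn E in compound 3 and Z in compound 4. The nearest measured precedent is a step that the two limits leave unreadable from compound 1 to compound 2, the same turn of the double bond, as the fact that compounds 1 and 2 differ only in the configuration as drawn records. The other measured step is a step that the two limits leave unreadable from compound 1 to compound 3, with dimethylamino in place of methoxy on an aromatic carbon. For the measured compounds named here, neither gives a size or a direction, and the only firm guide is the limit of > 5000 nM in this assay, at which 3 of the 3 values shown sit, as the common position of the series. The expected size is a step that the limit leaves unreadable from compound 3 to compound 4, with no direction the data can support and no step beyond the scatter firmly expected. Compound 4 is estimated at 7000 nM, with an expected range from 1500 nM to 20000 nM, and will most likely be reported only as a limit.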

Compound 4, half-maximal inhibitory concentration: 2750 nM
Compound 4: middle estimate off by 2.5-fold (0.41 log units), on the high side; measured number inside the range.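

In this assay, for the compounds shown here, compound 4 is the only one of the four compounds to give a number rather than a limit, so dimethylamino together with the Z double bond is the one combination with a reading of its own. Going by these compounds alone, the data now give an at least 1.8-fold lower number from compound 3 to compound 4 (0.25 log units; that floor lies within the scatter) and an at least 1.8-fold lower number from compound 2 to compound 4 (0.25 log units; that floor lies within the scatter), whereas the earlier steps among compound 1, compound 2 and compound 3 cannot be read. The first of these two steps isolates the turn of the double bond, with nothing else altered: the fact that compounds 3 and 4 differ only in the configuration as drawn.

On these data alone, how far either step really reaches stays open, as both are floors set by limits. The compounds shown also leave open whether another amine, such as pyrrolidine, or a carboxylic acid in place of a nitro group would change the reading.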